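Replacing Cyclohexylamino with Piperidin-1-yl on the Shared Core

This account rests on a few compounds, and the source may have more. Where it says the series, first, only, none or still open, it means among the compounds named here.

Of the compounds shown here, three built on one shared core have been tested in a functional assay on ECa-109 cells for inhibition, with ECa-109 cell line (Homo sapiens) as the target, read by sulforhodamine B assay; on this read-out higher numbers stand for weaker inhibition and lower numbers for stronger inhibition. Compound 1 `CCc1ccc(NC2=CC(=O)c3nc4n(c3C2=O)[C@H]2OC[C@@H](O)[C@H]2OC4)cc1` gives 3080 nM, and compound 2 `O=C1C=C(Nc2cccc(Cl)c2)C(=O)c2c1nc1n2[C@H]2OC[C@@H](O)[C@H]2OC1` gives 4690 nM. Compound 3 `O=C1C=C(NC2CCCCC2)C(=O)c2c1nc1n2[C@H]2OC[C@@H](O)[C@H]2OC1` yields only a limit of the assay, > 16000 nM. Both steps toward compound 3 lie beyond the scatter: an at least 5.1-fold higher number from compound 1 to compound 3 (0.71 log units; beyond the scatter) and an at least 3.4-fold higher number from compound 2 to compound 3 (0.53 log units; beyond the scatter). Compound 3 therefore stands as the weakest of the three, sitting at the limit of > 16000 nM in this assay, at which 1 of the 3 values shown sits. Compound 4 `O=C1C=C(N2CCCCC2)C(=O)c2c1nc1n2[C@H]2OC[C@@H](O)[C@H]2OC1` differs from compound 3 in one place: piperidin-1-yl in place of cyclohexylamino on a double-bonded ring carbon. Within the data shown here, no measured step covers this exact change; the two steps to compound 3 show only that the starting point is already weak. A similar or weaker result is expected, and the step is estimated as a step that the limit leaves unreadable from compound 3 to compound 4. Compound 4 is estimated at 20000 nM, between 8000 nM and 60000 nM, with a fair chance that the assay again returns only a limit.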

Compound 4, half-maximal inhibitory concentration: > 8000 nM
Compound 4 was reported as a limit (the forecaster's own chance of this, stated with the estimate: 70%); the middle value lies beyond the limit too.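

Compound 4 shows that piperidin-1-yl on this double-bonded ring carbon, with 0 hydrogen-bond donors, also returns only a limit in this assay. Set against the anilines, the change gives an at least 2.5-fold higher number from compound 1 to compound 4 (0.41 log units; beyond the scatter), and it gives an at least 1.7-fold higher number from compound 2 to compound 4 (0.23 log units; that floor lies within the scatter), so only the first of these is a firm loss. The step between compound 3 and compound 4 cannot be read, as both values are limits.

From the compounds shown here alone, how far either compound lies past its limit stays open. So does whether morpholin-4-yl or an open-chain diethylamino group would do better at this place.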